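This account rests on a few compounds, and the source may have more. Where it says the series, first, only, none or still open, it means among the compounds named here.

Values in a functional assay on St-4 cells (Homo sapiens) for inhibition, read by sulforhodamine B assay, with a stated time of 48 h; a higher number here means a weaker inhibitor of growth, a lower number a stronger inhibitor of growth:
compound 1 `CCCCCCCCCCCC[C@@H](O)[C@H]1CC[C@H]([C@H](O)CCCCCCCCCCNC(=O)c2ccnn2C)O1`: 18200 nM
compound 2 `CCCCCCCCCCCC[C@@H](O)[C@H]1CC[C@H]([C@H](O)CCCCCCCCCCNCc2ccnn2C)O1`: 1820 nM
compound 3 `CCCCCCCCCCCC[C@@H](O)[C@H]1CC[C@H]([C@H](O)CCCCCCCCCCC(=O)Nc2ccnn2C)O1`: 100000 nM

Compound 3 has the highest number of the three and is the weakest inhibitor of growth here, since both of its gaps lie beyond the scatter: a 5.5-fold higher number from compound 1 to compound 3 (0.74 log units; beyond the scatter) and a 55-fold higher number from compound 2 to compound 3 (1.74 log units; beyond the scatter).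

The next compound, compound 4 `CCCCCCCCCCCC[C@@H](O)[C@H]1CC[C@H]([C@H](O)CCCCCCCCCCOC(=O)c2ccnn2C)O1`, has not yet been measured. Its difference from compound 3 is ((1-methyl-1H-pyrazol-5-yl)carbonyl)oxy in place of (1-methyl-1H-pyrazol-5-yl)carbamoyl on a saturated chain carbon, ten or more bonds along the chain from an oxygen on a saturated carbon and a saturated ring carbon. The closest guide is compound 1, which carries the same (1-methyl-1H-pyrazol-5-yl)carbonyl unit, but on an amine nitrogen. The modest step of a 5.5-fold higher number from compound 1 to compound 3 (0.74 log units; beyond the scatter) therefore suggests that compound 4 could recover some activity. The larger step of a 10-fold lower number from compound 1 to compound 2 (1.00 log units; beyond the scatter) bears less directly, as it removes the carbonyl altogether. For the measured compounds named here, no compound with the ester link has been measured, so this reasoning remains uncertain. A modest move to a lower number is expected, an estimated 4.5-fold lower number from compound 3 to compound 4 (0.66 log units; beyond the scatter). For compound 4 the estimated value is 22000 nM, with an expected range of 6500 nM to 75000 nM.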

Compound 4, concentration for 50% growth inhibition: 30200 nM
The estimate for compound 4 lay 1.4-fold (0.14 log units) below the measured number, within the range that was stated.
By their numbers in this assay, from the lowest: compound 2; then compounds 1 and 4 (each within the scatter of the next); then compound 3.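

In this assay, ((1-methyl-1H-pyrazol-5-yl)carbonyl)oxy on the saturated chain carbon gives a 3.3-fold lower number from compound 3 to compound 4 (0.52 log units; beyond the scatter) as a modest step, while the comparison with the ((1-methyl-1H-pyrazol-5-yl)carbonyl)amino link gives a 1.7-fold higher number from compound 1 to compound 4 (0.22 log units; within the scatter) and so shows no readable difference between these two links. The ((1-methyl-1H-pyrazol-5-yl)methyl)amino link remains well separated from the ester, with a 17-fold higher number from compound 2 to compound 4 (1.22 log units; beyond the scatter) as a large step. Nothing measured here explains these differences.

The compounds shown leave open whether an ether or a sulfonamide link at this chain carbon would behave like the ester or like the amine of compound 2. They also leave open how a tertiary amine or a longer chain would read in this assay.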